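This account rests on a few compounds, and the source may have more. Where it says the series, first, only, none or still open, it means among the compounds named here.

Three compounds have been measured in a functional assay on SK-BR-3 cells (Homo sapiens) for inhibition, read by MTT assay, with a stated time of 2 days, tested at 100 uM; on this read-out lower numbers stand for less inhibition of growth and higher numbers for more inhibition of growth at the one concentration tested:
compound 1, `CNC(=O)c1cc(Oc2ccc3nc(NC(=O)Nc4ccc(Br)cc4)sc3c2)ccn1`, giving 69.2%;
compound 2, `CNC(=O)c1cc(Oc2ccc3nc(NC(=O)c4ccc(Cl)cc4)sc3c2)ccn1`, giving 83%;
compound 3, `CNC(=O)c1cc(Oc2ccc3nc(NC(=O)Nc4ccc(Cl)cc4)sc3c2)ccn1`, giving 77.4%.

Compound 3 stands second of the three, yet its gap to compound 2 and its gap to compound 1 both stay within the scatter, so no order among them can be asserted. Compound 4, `CNC(=O)c1cc(Oc2ccc3nc(NC(=O)c4ccc(Cl)cc4Cl)sc3c2)ccn1`, differs from compound 3 by 2,4-dichlorophenyl in place of (4-chlorophenyl)amino on a carbonyl carbon. The measured step that bears on this most directly is a number 5.6 percentage points lower from compound 2 to compound 3 (within the scatter), which runs the opposite way and differs from the present change only in the chloro groups on the phenyl. The step of a number 13.8 percentage points higher from compound 1 to compound 2 (beyond the scatter) combines the same swap at the carbonyl with a halogen change and is modest. Compound 4 is therefore expected to show a step of a number 4.6 percentage points higher from compound 3 to compound 4 (within the scatter). Compound 4 is estimated at 82%, between 70% and 92%.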

Compound 4, percent growth inhibition at one concentration: 81%
For compound 4 the middle estimate is 1 percentage points above the measured one, and the stated range covers the measured number.
By their numbers in this assay, from the lowest: compounds 1, 3, 4 and 2 (each within the scatter of the next, the first and the last beyond it).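

In this assay the extra chloro on the phenyl gives a number 2 percentage points lower from compound 2 to compound 4 (within the scatter) and so adds nothing that can be told apart from repeat scatter. Among these compounds, putting 2,4-dichlorophenyl in place of (4-chlorophenyl)amino on the carbonyl carbon removes a hydrogen-bond donor and gives a number 3.6 percentage points higher from compound 3 to compound 4 (within the scatter) while the same group in place of (4-bromophenyl)amino gives a number 11.8 percentage points higher from compound 1 to compound 4 (beyond the scatter) and is the only new step to clear the scatter. Nothing measured here explains these numbers.

On these data alone, whether a methoxy group or an amine in place of a chloro on this phenyl ring would shift the read-out remains open.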